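Propyl Replaces Cyclohexyl on the Ether Oxygen

A few compounds are considered here, and "the series" means these few. Any claim that something is new, unique, unknown or untested is made for them only; others in the source may bear on it.

The series rests on a shared core carrying an ether-linked side chain. For the measured compounds named here, compound 1 `COc1ccc2c(c1)[n+]([O-])nc(NCOC(C)c1ccccc1)[n+]2[O-]` and compound 2 `[O-][n+]1nc(NCOC2CCCCC2)[n+]([O-])c2ccccc21` are the two measured members. In a functional assay on PC-3 cells (Homo sapiens) for cytotoxicity, read by MTT assay, with a stated time of 72 h (a lower number here means a stronger inhibitor, a higher number a weaker inhibitor), compound 1 gives 4140 nM. In this assay compound 2 gives 3250 nM, the lower of the two numbers, though its gap to compound 1 lies within the scatter, so the two cannot be separated on these values alone.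

Compound 3 `CCCOCNc1n[n+]([O-])c2ccccc2[n+]1[O-]` is not yet measured. It differs from compound 2 in one place: propyl in place of cyclohexyl on an oxygen on a saturated carbon. Going by the values given here, nothing in the two measured compounds tests this particular change, since compound 1 and compound 2 differ from each other in more than one respect and no single-point step exists between them.

Both measured numbers sit in the same narrow band, which suggests the side chain tolerates some variation. On that basis the expected step from compound 2 to compound 3 in this assay is a 1.5-fold higher number from compound 2 to compound 3 (0.17 log units; within the scatter), a modest loss if any, not clearly beyond the scatter. Compound 3 is therefore estimated at 4800 nM, within a range of 2000 nM to 12000 nM.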

Compound 3, half-maximal inhibitory concentration: 14200 nM
For compound 3 the middle estimate is 3.0-fold (0.47 log units) below the measured one; measured number outside the range, above it.
By their numbers in this assay, from the lowest: compounds 2 and 1 (each within the scatter of the next); then compound 3.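

In this assay, for the compounds shown here, the exchange of cyclohexyl for propyl on an oxygen on a saturated carbon gives the first step that changes one place only: a 4.4-fold higher number from compound 2 to compound 3 (0.64 log units; beyond the scatter). The earlier pair could not show this, since compound 1 and compound 2 differ in more than one respect, and their closeness said nothing about the group on this oxygen taken alone; the step shows that the number does respond to that group, and that a simple open chain does not stand in for the ring here. The change removes the six-membered ring and takes the group from 6 heavy atoms to 3 in a single move, and no measurement offered here explains why the number rises.

The compounds shown leave open whether the ring itself or the carbon count carries the step, a question that a straight hexyl chain on the same oxygen would address. They also leave open how an amine on this chain would read, and whether the same exchange gives a similar step on the core of compound 1.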